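Working notes: from compound 2 to compound 3

A few compounds are considered here, and "the series" means these few. Any claim that something is new, unique, unknown or untested is made for them only; others in the source may bear on it.

- compound 1 `CNC(=O)c1cc(C(=O)N[C@H]2CC[C@H](OC)CC2)c([C@@H](C)c2ccccc2)o1`: 4.1
- compound 2 `CNC(=O)c1cc(C(=O)N[C@H]2CC[C@H](O)CC2)c([C@@H](C)c2ccc(C)cc2)o1`: 3.4

In a physicochemical assay for lipophilicity (on this read-out lower numbers stand for lower lipophilicity and higher numbers for higher lipophilicity), compound 2 gives 3.4, the lower of the two numbers, and compound 1 stands higher at 4.1, a gap beyond the scatter. Compound 3 `CNC(=O)c1cc(C(=O)N[C@H]2CC[C@H](O)CC2)c([C@@H](C)c2ccccc2)o1` differs from compound 2 by one change, hydrogen in place of methyl on an aromatic carbon. Among the compounds with values here, no measured pair shows this change alone, so the expectation has no direct precedent. A modest fall in this assay is expected, with the estimated step of a number 0.30 log units lower from compound 2 to compound 3 (within the scatter). For compound 3 the estimated value is 3.1, with an expected range of 2.8 to 3.4.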

Compound 3, distribution coefficient: 2.8
Compound 3: the middle estimate sits 0.30 log units above what was measured, within the range that was stated.
By their numbers in this assay, from the lowest: compound 3; then compound 2; then compound 1.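

Within the data shown here, compound 3 gives the first single-change readings in this set, both beyond the scatter. In this assay, 4-methylphenyl to phenyl, on an aromatic carbon para to a large group, gives a modest step (a number 0.60 log units lower from compound 2 to compound 3 (beyond the scatter)). Hydrogen in place of methyl on an oxygen on a saturated carbon gives a large one (a number 1.30 log units lower from compound 1 to compound 3 (beyond the scatter)), and no supporting data account for either step.

From the compounds shown here alone, whether a chlorine or a longer chain at the para position would shift this assay in the same way remains open. So does the effect of an amine in place of the hydroxyl.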